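Replacing pyridinylpiperazinyl with piperidinyl: an expected cell result

A few compounds are considered here, and "the series" means these few. Any claim that something is new, unique, unknown or untested is made for them only; others in the source may bear on it.

Measured compounds:
compound 1 `COc1ccc(NC(=O)Nc2nc(Sc3c[nH]c4ccccc34)cc(N3CCCCC3)n2)cc1`, 17100 nM
compound 2 `COc1ccc(NC(=O)Nc2nc(Sc3c[nH]c4ccccc34)cc(N3CCN(c4ccccn4)CC3)n2)cc1`, 11400 nM
compound 3 `O=C(Nc1ccccc1)Nc1nc(Sc2c[nH]c3ccccc23)cc(N2CCN(c3ccccn3)CC2)n1`, 8930 nM

All three were tested in a functional assay on HepG2 cells (Homo sapiens) for inhibition, with a stated time of 72 h; a higher number here means a weaker inhibitor, a lower number a stronger inhibitor. From compound 2 to compound 1 the change is piperidin-1-yl in place of 4-(pyridin-2-yl)piperazin-1-yl on an aromatic carbon, and it gave a 1.5-fold higher number from compound 2 to compound 1 (0.18 log units; within the scatter). From compound 2 to compound 3 the change is hydrogen in place of methoxy on an aromatic carbon, giving a 1.3-fold lower number from compound 2 to compound 3 (0.11 log units; within the scatter). The three values sit close together, all within the usual scatter of one another.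

Compound 4 `O=C(Nc1ccccc1)Nc1nc(Sc2c[nH]c3ccccc23)cc(N2CCCCC2)n1` differs from compound 3 by piperidin-1-yl in place of 4-(pyridin-2-yl)piperazin-1-yl on an aromatic carbon. This is the same kind of change as that from compound 2 to compound 1; the surroundings differ in that the group in compound 1 is meta to a ((4-methoxyphenyl)carbamoyl)amino group, whereas in compound 4 it is meta to a (phenylcarbamoyl)amino group. The two cores differ by hydrogen in place of methoxy on an aromatic carbon.

For compound 4 a step of a 1.5-fold higher number from compound 3 to compound 4 (0.16 log units; within the scatter) is expected, resting on the earlier 1.5-fold higher number from compound 2 to compound 1 (0.18 log units; within the scatter) in the matched pair. Compound 4 is therefore estimated at 13000 nM, with a likely range from 6000 nM to 30000 nM.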

Compound 4, half-maximal inhibitory concentration: 20900 nM
Estimate against measurement, compound 4: 1.6-fold (0.21 log units) below; low and high end bracket the measured number.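

In this assay, piperidin-1-yl in place of 4-(pyridin-2-yl)piperazin-1-yl gave a 2.3-fold higher number from compound 3 to compound 4 (0.37 log units; beyond the scatter), and this step agrees with the one on the methoxy-bearing core: the same change on two cores in this assay, a 1.5-fold higher number (0.18 log units; within the scatter) from compound 2 to compound 1 and a 2.3-fold higher number (0.37 log units; beyond the scatter) from compound 3 to compound 4, 1.6-fold (0.19 log units) apart, within the scatter of two such steps. Hydrogen in place of methoxy gave a 1.2-fold higher number from compound 1 to compound 4 (0.09 log units; within the scatter), which also agrees with its counterpart on the other core: the same change on two cores in this assay, a 1.3-fold lower number (0.11 log units; within the scatter) from compound 2 to compound 3 and a 1.2-fold higher number (0.09 log units; within the scatter) from compound 1 to compound 4, 1.6-fold (0.19 log units) apart, within the scatter of two such steps. The change therefore carried across these two cores, but this rests on a single pair of steps, only one of which lies beyond the scatter, and it does not show that the change would carry to any other core.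

On these data alone, it remains open how morpholin-4-yl or an open-chain amine would compare with piperidin-1-yl. As far as these compounds go, the effect of a chlorine on the phenyl ring of the (phenylcarbamoyl)amino group is also open.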